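Swapping One Ring on the Higher-Exposure Compound

The compounds below may be only part of what the source reports. "The series", "measured", "known", "first", "only" and "open" are said of these compounds alone.

Oral exposure shows how much of a compound reaches the blood after swallowing, and here it is followed in an ADME assay on the whole organism (Mus musculus, strain CD-1) for pharmacokinetics, at a dose of 10 mg/kg by the oral route; on this read-out lower numbers stand for lower exposure and higher numbers for higher exposure at the dose given. Of the compounds shown here, two have been measured so far. Compound 1 `CCOc1cc([C@](O)(CCN(C)C)[C@@H](c2cc3cc(Br)ccc3nc2OC)c2cccc(OC)c2F)cc(OC)n1` gives 4000 ng.h/mL, while compound 2 `CCOc1cc([C@](O)(CCN(C)C)[C@H](c2cccc(C)c2)c2cc3cc(Br)ccc3nc2OC)cc(OC)n1` gives 9400 ng.h/mL, the higher of the two numbers. The next structure is compound 3 `CCOc1cc([C@](O)(CCN(C)C)[C@@H](c2cc3cc(Br)ccc3nc2OC)c2ccnc(OC)c2OC)cc(OC)n1`, which changes a single group of compound 2: 2,3-dimethoxypyridin-4-yl in place of 3-methylphenyl on a saturated chain carbon bound to an aromatic carbon and a saturated chain carbon. Going by the values given here, only one measured step bears on this change. Replacing 2-fluoro-3-methoxyphenyl with 3-methylphenyl gave a 2.4-fold higher number from compound 1 to compound 2 (0.37 log units; beyond the scatter), a modest rise beyond the scatter. Among the compounds with values here, compound 3 gives up the same 3-methylphenyl group for a ring that, like the one in compound 1, carries methoxy groups, so that step is read in reverse as a rough guide. Within the data shown here, no pyridine-bearing compound has been measured yet, so this guide is weak. The expected change is a 2.1-fold lower number from compound 2 to compound 3 (0.32 log units; beyond the scatter), a modest fall. For compound 3 the estimated exposure is 4500 ng.h/mL, with an expected range from 1500 ng.h/mL to 11000 ng.h/mL.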

Compound 3, area under the concentration-time curve: 12700 ng.h/mL
Estimate against measurement, compound 3: 2.8-fold (0.45 log units) below; the whole stated range lies below it.
By their numbers in this assay, from the lowest: compound 1; then compounds 2 and 3 (each within the scatter of the next).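

The two rings differ in size and make-up, yet putting 2,3-dimethoxypyridin-4-yl in place of 3-methylphenyl on this saturated chain carbon gives a 1.4-fold higher number from compound 2 to compound 3 (0.13 log units; within the scatter), so this assay does not separate the two compounds. Going by these compounds alone, putting the same pyridine ring in place of 2-fluoro-3-methoxyphenyl gives a 3.2-fold higher number from compound 1 to compound 3 (0.50 log units; beyond the scatter), which shows that methoxy groups on the ring do not in themselves go with the lower number, as the single earlier step might have suggested; compound 1 and compound 3 both carry them, and only compound 1 stands apart from the other two. This position therefore keeps the higher exposure with either a carbon-only ring or a larger ring holding a nitrogen, although nothing available here explains the difference between these compounds.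

Which feature of the 2-fluoro-3-methoxyphenyl ring sets compound 1 apart remains open, and a ring carrying the fluorine alone or the methoxy alone would help to separate the two. On these data alone, it is also open whether the exposure would hold with a plain phenyl ring or with a ring bearing an amine or a carboxylic acid at this position.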